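A few compounds are considered here, and "the series" means these few. Any claim that something is new, unique, unknown or untested is made for them only; others in the source may bear on it.

Compound 1 `O=C1Nc2ccccc2/C1=N/NC(=S)Nc1cccc(Cl)c1` and compound 2 `O=C1Nc2ccccc2/C1=N/NC(=S)Nc1ccc(Cl)cc1` share one core and differ only in where the chlorine sits on the outer ring. In a functional assay on KB 3-1 cells (Homo sapiens) for cytotoxicity, read by MTT assay, with a stated time of 72 h (a lower number here means a stronger inhibitor, a higher number a weaker inhibitor), compound 1 gives 1870 nM, while compound 2 gives 13400 nM. Among the compounds with values here, the single measured step, a 7.2-fold higher number from compound 1 to compound 2 (0.86 log units; beyond the scatter), is therefore the whole of the known record, and compound 2 stands with the highest of the two numbers, its nearest neighbour being compound 1 at a lower value.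

Compound 3 `CCCC1CCC(c2ccc(NC(=S)N/N=C3\C(=O)Nc4ccccc43)cc2)CC1` is the next compound in line. It differs from compound 2 by 4-propylcyclohexyl in place of chloro on an aromatic carbon. Within the data shown here, no measured step bears directly on this change: the only step known moves a chloro from one position to another and never replaces it with a larger group, so that step offers little guidance beyond showing that the outer ring tolerates modest change with a modest shift. The step is thus expected to be uncertain in direction, and a 1.7-fold lower number from compound 2 to compound 3 (0.22 log units; within the scatter) is the estimated outcome. On that basis compound 3 is expected to give about 8000 nM, within a range from 2000 nM to 30000 nM.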

Compound 3, half-maximal inhibitory concentration: 17500 nM
Estimate against measurement, compound 3: 2.2-fold (0.34 log units) below; measured number inside the range.
By their numbers in this assay, from the lowest: compound 1; then compounds 2 and 3 (each within the scatter of the next).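

In this assay, putting 4-propylcyclohexyl, with its 9 carbon atoms and non-aromatic ring, in place of the single chlorine gives a 1.3-fold higher number from compound 2 to compound 3 (0.12 log units; within the scatter) and so leaves the two compounds within the usual scatter of each other. The earlier step, a 7.2-fold higher number from compound 1 to compound 2 (0.86 log units; beyond the scatter), came from moving the chlorine alone and lay beyond the scatter, whereas this much larger replacement on the same aromatic carbon produces no difference that can be told from scatter, so in this pair, the size of the group entering at this place does not show up in the number. No measurement shown here accounts for this match between compound 2 and compound 3.

From the compounds shown here alone, whether this tolerance extends to other kinds of group on this aromatic carbon, such as an amine, a carboxylic acid or a simple longer chain, remains open. Within the data shown here, it is also open whether 4-propylcyclohexyl would give a similar number at the ring place where compound 1 carries its chlorine, the one change so far to give a step beyond the scatter.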